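The source may report more compounds than this note shows. Statements on the series, on what has been measured and on what is new or still open speak of the compounds shown alone.

Of the compounds shown here, three have been measured in an ADME assay on BHK-21 cells (Mesocricetus auratus) for cytotoxicity, read by MTT assay, with a stated time of 72 h; on this read-out lower numbers stand for higher toxicity in this test and higher numbers for lower toxicity in this test.
Compound 1, `Cc1ccc(-c2nn(-c3ccccc3)cc2CNc2ccccc2)cc1`, gives > 100000 nM, which is a limit of the assay and not a number.
Compound 2, `FC(F)(F)c1ccc(NCc2cn(-c3ccccc3)nc2-c2ccc(Br)cc2)cc1`, gives 20000 nM.
Compound 3, `Clc1ccc(NCc2cn(-c3ccccc3)nc2-c2ccc(Cl)cc2)cc1`, gives 73000 nM.

Of the two numbers in this assay, compound 3 stands highest; its nearest neighbour is compound 2, whose number is lower by a margin beyond the usual scatter. Among the compounds with values here, the remaining value is the one at which compound 1 sits, (the limit of > 100000 nM in this assay, at which 1 of the 3 values shown sits).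

Compound 4, `Cc1ccc(NCc2cn(-c3ccccc3)nc2-c2ccc(Cl)cc2)cc1`, has not yet been measured in this assay. It differs from compound 3 in one place: methyl in place of chloro on an aromatic carbon. Within the data shown here, no measured pair shares a change of this kind, so the direction of the step is not fixed by a measured step. In this assay compound 1 sits at the limit, and compound 3 already stands highest of the numbers.

Compound 4 is expected in this assay at 100000 nM, in a range from 40000 nM to 250000 nM. The expected step of a 1.4-fold higher number from compound 3 to compound 4 (0.14 log units; within the scatter) points toward a higher number, that is lower toxicity, and may well stay within the scatter.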

Compound 4, half-maximal cytotoxic concentration: > 100000 nM
Compound 4 gave a limit, no number; the forecaster's own chance of this, stated with the estimate: 45%; the middle value lies on the limit itself.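

In this assay, the change from (4-chlorophenyl)amino to (4-methylphenyl)amino gives the first step read at this position: an at least 1.3-fold higher number from compound 3 to compound 4 (0.13 log units; that floor lies within the scatter). Compound 4 gives a limit of the assay and not a number, and with it a second value now sits there: the limit of > 100000 nM in this assay, at which 2 of the 4 values shown sit. The step can therefore be read only as a floor, pointing toward a higher number, that is lower toxicity in this test, and that floor alone does not carry the change beyond the scatter.

The compounds shown leave open how large the true step from chloro to methyl is. They also leave open what an amine, a carboxylic acid or a methoxy group on this aromatic carbon would give in this assay.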